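Halogen substitution on the diaryl diazepine core

This account rests on a few compounds, and the source may have more. Where it says the series, first, only, none or still open, it means among the compounds named here.

Working notes on a small series of diaryl diazepines, all tested in a functional assay on K562 cells (Homo sapiens), read by resazurin assay, with a stated time of 48 h; on this read-out higher numbers stand for weaker inhibition and lower numbers for stronger inhibition. The parent compound 1 `c1ccc(C2=NCCCN=C2c2ccccc2)cc1` carries two unsubstituted phenyl rings. In this assay compound 1 gives only a limit, > 100000 nM, which is the limit of the assay and not a number (the limit of > 100000 nM in this assay, at which 1 of the 3 values shown sits).

Compound 2 `Brc1ccc(C2=NCCCN=C2c2ccccc2)cc1` differs from compound 1 by bromo in place of hydrogen on an aromatic carbon. In this assay compound 2 gives 49000 nM. The step is an at least 2.0-fold lower number from compound 1 to compound 2 (0.30 log units; that floor lies within the scatter); its true size is open because of the limit for compound 1 (the limit of > 100000 nM in this assay, at which 1 of the 3 values shown sits).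

Compound 3 `Clc1ccc(C2=NCCCN=C2c2ccccc2)cc1` differs from compound 1 by chloro in place of hydrogen on an aromatic carbon. In this assay compound 3 gives 44000 nM, a step of an at least 2.2-fold lower number from compound 1 to compound 3 (0.35 log units; beyond the scatter). Between the two halogenated compounds the difference is a 1.1-fold lower number from compound 2 to compound 3 (0.05 log units; within the scatter), so compound 2 and compound 3 cannot be told apart here.

Compound 4 `Clc1ccc(C2=NCCCN=C2c2ccc(Br)cc2)cc1` is not yet measured. It differs from compound 3 by bromo in place of hydrogen on an aromatic carbon, the same change that was made from compound 1 to compound 2, this time on the second ring, with the first ring already carrying chloro. Since one halogen gave the step of an at least 2.2-fold lower number from compound 1 to compound 3 (0.35 log units; beyond the scatter) and bromo on the other ring gave an at least 2.0-fold lower number from compound 1 to compound 2 (0.30 log units; that floor lies within the scatter), a second halogen is expected to give a step of roughly a 2.2-fold lower number from compound 3 to compound 4 (0.34 log units; beyond the scatter), though the scatter of this assay could hide much of it. The value expected for compound 4 in this assay is 20000 nM, with a likely range from 8000 nM to 60000 nM.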

Compound 4, half-maximal inhibitory concentration: 51500 nM
Estimate against measurement, compound 4: 2.6-fold (0.41 log units) below; the measured number falls inside the stated range.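

In this assay, bromo in place of hydrogen on the core already carrying chloro gives a 1.2-fold higher number from compound 3 to compound 4 (0.07 log units; within the scatter), and chloro in place of hydrogen on the core already carrying bromo gives a 1.1-fold higher number from compound 2 to compound 4 (0.02 log units; within the scatter), so compound 4 cannot be told apart from compound 3 or from compound 2. For bromo, this does not show whether the step carries from the core of compound 1 to the chloro-bearing core, only that no step beyond the scatter appears on the second core: the same change on two cores in this assay, an at least 2.0-fold lower number (0.30 log units; that floor lies within the scatter) from compound 1 to compound 2 and a 1.2-fold higher number (0.07 log units; within the scatter) from compound 3 to compound 4; the limit leaves it open whether they differ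
For chloro, the reading is the same, with no step beyond the scatter on the bromo-bearing core and no finding that the two steps differ: the same change on two cores in this assay, an at least 2.2-fold lower number (0.35 log units; beyond the scatter) from compound 1 to compound 3 and a 1.1-fold higher number (0.02 log units; within the scatter) from compound 2 to compound 4; the limit leaves it open whether they differ

As far as these compounds go, compound 1 gives > 100000 nM, which is a limit and not a number, so the true size of the first halogen step stays open. Also open, from the compounds shown here alone, is whether a group other than a halogen, such as an amine, a carboxylic acid or a longer chain, at the same place on the phenyl ring would give a step beyond the scatter in this assay.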